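Naphthyloxyacetyl hydrazones: cytotoxicity on HEL cells

The source may hold more compounds than are shown below. What is called first, only, known or untested is meant among the compounds shown, and "the series" means these compounds.

Measured so far:
compound 1 `C/C(=N\NC(=O)COc1cccc2ccccc12)c1cccc([N+](=O)[O-])c1` — 10.5 ug/mL
compound 2 `O=C(COc1cccc2ccccc12)N/N=C/c1cccc(O)c1` — 62.7 ug/mL

In an ADME assay on HEL cells (Homo sapiens) for cytotoxicity (a lower number here means that less compound is tolerated, a higher number that more compound is tolerated), compound 2 gives 62.7 ug/mL, the higher of the two numbers, and the gap to compound 1, which gives 10.5 ug/mL, is beyond the scatter. Compound 3 `COc1ccc(/C=N/NC(=O)COc2cccc3ccccc23)cc1` is not yet measured. Relative to compound 2 it carries 4-methoxyphenyl in place of 3-hydroxyphenyl on a carbon with a double bond to nitrogen. For the measured compounds named here, no step between measured compounds shows what this change does, so only a small step is expected from compound 2 to compound 3, a 1.4-fold lower number from compound 2 to compound 3 (0.14 log units; within the scatter), within or near the scatter, with a wide band of uncertainty. Compound 3 is estimated at 45 ug/mL, between 15 ug/mL and 120 ug/mL.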

Compound 3, half-maximal cytotoxic concentration: 100 ug/mL
The estimate for compound 3 lay 2.2-fold (0.35 log units) below the measured number; low and high end bracket the measured number.
By their numbers in this assay, from the lowest: compound 1; then compounds 2 and 3 (each within the scatter of the next).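

On the carbon with a double bond to nitrogen, 4-methoxyphenyl in place of 3-hydroxyphenyl gives, in this assay, a 1.6-fold higher number from compound 2 to compound 3 (0.20 log units; within the scatter), so this exchange is not resolved from the scatter. The hydrogen-bond donor of 3-hydroxyphenyl is absent from 4-methoxyphenyl, yet the step stays within the scatter. No available evidence bears on the reason for this result.

Still open, on these data alone, is whether an amine or a carboxylic acid on this aromatic ring would give a step beyond the scatter. The gap to compound 1 also remains unassigned, since that compound differs from compound 2 and compound 3 in more than one place.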